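A few compounds are considered here, and "the series" means these few. Any claim that something is new, unique, unknown or untested is made for them only; others in the source may bear on it.

Compound 1 `CC(C)C(NC(=O)Cn1c(-c2ccccc2)ccc(N)c1=O)C(=O)C(F)(F)F`: 490 ug/mL
Compound 2 `COc1ccc(Cn2c(=O)[nH]c3c(=O)n(CC(=O)NC(C(=O)C(F)(F)F)C(C)C)c(-c4ccccc4)cc3c2=O)cc1`: 230 ug/mL
Compound 3 `CC(C)C(NC(=O)Cn1c(-c2ccccc2)cc2c(=O)n(N(C)C)c(=O)[nH]c2c1=O)C(=O)C(F)(F)F`: 320 ug/mL

In a physicochemical assay for solubility, in phosphate buffer (on this read-out lower numbers stand for lower solubility and higher numbers for higher solubility), compound 3 gives 320 ug/mL, the second highest of the three numbers; the values of compound 2 and compound 1 both lie within the scatter of it. Compound 4 `CC(C)C(NC(=O)Cn1c(-c2ccccc2)cc2c(=O)n(CC(N)=O)c(=O)[nH]c2c1=O)C(=O)C(F)(F)F` differs from compound 3 by carbamoylmethyl in place of dimethylamino on an aromatic nitrogen. Among the compounds with values here, the only measured step at this same aromatic nitrogen is a 1.4-fold higher number from compound 2 to compound 3 (0.14 log units; within the scatter), which stayed within the scatter. That step also exchanged one group for another at this place, so it is the one that bears on the new change. Because a 1.4-fold higher number from compound 2 to compound 3 (0.14 log units; within the scatter) stayed within the scatter, no step beyond the scatter is expected here: a 1.1-fold higher number from compound 3 to compound 4 (0.04 log units; within the scatter). Compound 4 is therefore estimated at 350 ug/mL, with a range from 150 ug/mL to 800 ug/mL.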

Compound 4, solubility: 130 ug/mL
The estimate for compound 4 lay 2.7-fold (0.43 log units) above the measured number; measured number below the stated range.
By their numbers in this assay, from the lowest: compounds 4, 2, 3 and 1 (each within the scatter of the next, the first and the last beyond it).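

In this assay, the group on this aromatic nitrogen can move the number beyond the scatter: carbamoylmethyl in place of dimethylamino gives a 2.5-fold lower number from compound 3 to compound 4 (0.39 log units; beyond the scatter). The other step, carbamoyl in place of 4-methoxyphenyl on the saturated chain carbon, is smaller: a 1.8-fold lower number from compound 2 to compound 4 (0.25 log units; within the scatter). Nothing measured here accounts for the drop. Still open, as far as these compounds go, is where a plain amine or a carboxylic acid on a short chain at this nitrogen would fall. Also open, from the compounds shown here alone, is whether the hydrogen-bond donor that enters with carbamoylmethyl has any part in the step.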